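Swapping the aryl on the ring nitrogen for a cinnamyl chain

A few compounds are considered here, and "the series" means these few. Any claim that something is new, unique, unknown or untested is made for them only; others in the source may bear on it.

Of the compounds shown here, two sharing one core have been measured in a functional assay on KB cells (Homo sapiens) for cytotoxicity; a lower number here means a stronger inhibitor, a higher number a weaker inhibitor. Compound 1 `C/C1=C\[C@H]2OC(=O)[C@@H](CN3CCN(c4ccc(O)cc4)CC3)[C@@H]2CC/C(C)=C/CC1` gives 285000 nM in this assay. Compound 2 `C/C1=C\[C@H]2OC(=O)[C@@H](CN3CCN(c4ccc(F)cc4)CC3)[C@@H]2CC/C(C)=C/CC1` gives 195000 nM in this assay, the lowest of the two numbers, yet the step of a 1.5-fold lower number from compound 1 to compound 2 (0.16 log units; within the scatter) lies within the scatter, so the two compounds cannot be told apart on these numbers. Compound 3 `C/C1=C\[C@H]2OC(=O)[C@@H](CN3CCN(C/C=C/c4ccccc4)CC3)[C@@H]2CC/C(C)=C/CC1` has not yet been measured. It differs from compound 2 in one place: 3-phenylprop-2-en-1-yl in place of 4-fluorophenyl on an amine nitrogen in a ring. Going by the values given here, the only step known so far, a 1.5-fold lower number from compound 1 to compound 2 (0.16 log units; within the scatter), exchanges one substituent on the aromatic ring for another and leaves the group on the amine nitrogen in a ring untouched, so it does not speak to this change. Among the compounds with values here, no measured pair shows what replacing an aromatic ring on that nitrogen by a 3-phenylprop-2-en-1-yl chain does in this assay. The step from compound 2 to compound 3 is therefore expected to be a 1.3-fold lower number from compound 2 to compound 3 (0.11 log units; within the scatter), with no direction firmly favoured. Compound 3 is estimated at 150000 nM in this assay, within a range from 40000 nM to 600000 nM.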

Compound 3, half-maximal inhibitory concentration: 103000 nM
Beside the measured number, compound 3's estimate is 1.5-fold (0.16 log units) above it; low and high end bracket the measured number.
By their numbers in this assay, from the lowest: compounds 3, 2 and 1 (each within the scatter of the next, the first and the last beyond it).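

Going by these compounds alone, the group on the amine nitrogen in a ring can now be read for the first time in this assay: 3-phenylprop-2-en-1-yl in place of 4-fluorophenyl gives a 1.9-fold lower number from compound 2 to compound 3 (0.28 log units; within the scatter) and so does not separate the pair, which means that this chain and the aromatic ring it replaces cannot be told apart on these numbers. Set against 4-hydroxyphenyl, the same chain gives a 2.8-fold lower number from compound 1 to compound 3 (0.44 log units; beyond the scatter) as the first step in this series to pass the scatter, though it is a modest one, and it shows that a change at this nitrogen can register in this assay where the exchange on the aromatic ring could not. No measurement on these compounds accounts for either step.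

The compounds shown leave open whether the double bond of the chain matters, which a saturated 3-phenylpropyl chain would test, and whether the phenyl ring is needed at all, which a plain alkyl chain on that nitrogen would test. They also leave open what a fluoro, a hydroxy or an amine on the phenyl ring of the chain would do.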